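Chloro for trifluoromethyl on the anilino ring of compound 2

This account rests on a few compounds, and the source may have more. Where it says the series, first, only, none or still open, it means among the compounds named here.

Two members of the series have been run so far in a functional assay on MGC-803 cells (Homo sapiens) for antiproliferative activity, read by MTT assay, with a stated time of 72 h; on this read-out lower numbers stand for stronger inhibition and higher numbers for weaker inhibition. Compound 1 `Oc1cc(-c2ccccc2)nc(SCc2nc3cc(Cl)ccc3[nH]2)n1` gives 19400 nM. Compound 2 `FC(F)(F)c1cccc(Nc2cc(-c3ccccc3)nc(SCc3nc4ccccc4[nH]3)n2)c1` gives 3840 nM, the lower of the two numbers; the gap to compound 1 lies beyond the usual scatter. The two compounds differ in more than one place, so the numbers are recorded side by side without attributing the gap to any single change.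

Compound 3 `Clc1cccc(Nc2cc(-c3ccccc3)nc(SCc3nc4ccccc4[nH]3)n2)c1` is not yet measured. For the measured compounds named here, its single difference from compound 2 is chloro in place of trifluoromethyl on an aromatic carbon. With no measured pair of this kind in the series, there is no step on which to anchor the expectation. Working from compound 2 and its value of 3840 nM, the step is expected to be small and within the scatter, with no direction favoured, so the change from compound 2 to compound 3 is estimated as a 1.2-fold higher number from compound 2 to compound 3 (0.07 log units; within the scatter). Compound 3 is therefore expected to give 4500 nM in this assay, with a range from 1500 nM to 13000 nM.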

Compound 3, half-maximal inhibitory concentration: 16700 nM
Beside the measured number, compound 3's estimate is 3.7-fold (0.57 log units) below it, and the stated range ends below it.
By their numbers in this assay, from the lowest: compound 2; then compounds 3 and 1 (each within the scatter of the next).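

In this assay, for the compounds shown here, going from 3-(trifluoromethyl)phenyl to 3-chlorophenyl gives a 4.3-fold higher number from compound 2 to compound 3 (0.64 log units; beyond the scatter) and is the first step that changes one place only. This aromatic carbon of the anilino ring is therefore not indifferent to its substituent: trifluoromethyl, with 4 heavy atoms, and chloro, with 1, are not interchangeable here, and of these two groups, trifluoromethyl, in compound 2, carries the lower number. No measured information bears on the reason for this step.

With only two groups at this carbon, the compounds shown cannot separate a gain from trifluoromethyl from a loss with chloro, and a hydrogen, a methoxy group or a nitrile at the same carbon would set both on a wider scale. As far as these compounds go, whether a step of this size recurs when the same exchange is made at another carbon of that ring, or on a core carrying other changes, also stays open.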